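The source may report more compounds than this note shows. Statements on the series, on what has been measured and on what is new or still open speak of the compounds shown alone.

Compound 3 `COc1ccc(/C=C/c2cccc(O)c2)cc1` is the starting point. In an assay on HepG2 cells for activation of nuclear factor erythroid 2-related factor 2 (Homo sapiens), read by a luciferase reporter, with a stated time of 5 h (on this read-out higher numbers stand for an effect only at larger amounts of compound and lower numbers for an effect already at smaller amounts), compound 3 gives only a limit, > 15000 nM, and not a number. Compound 3 therefore sits at the limit of > 15000 nM in this assay, at which 1 of the 3 values shown sits. For comparison, compound 1 `COc1cccc(/C=C/c2cccc(F)c2)c1OC` gives 1900 nM in this assay, and compound 2 `COc1ccc(/C=C/c2cc(F)ccc2F)cc1` gives 3200 nM. Compound 4 `COc1ccc(/C=C/c2cccc([N+](=O)[O-])c2)cc1` has not yet been measured. It differs from compound 3 by nitro in place of hydroxy on an aromatic carbon. Within the data shown here, no measured pair of compounds shows what such a swap does in this assay, so the size of the step is open. A move toward lower numbers, beyond the usual scatter, is expected, namely an at least 3.0-fold lower number from compound 3 to compound 4 (0.47 log units; beyond the scatter). Compound 4 is estimated at 5000 nM, with a range from 1500 nM to 20000 nM.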

Compound 4, half-maximal effective concentration: 3300 nM
Estimate against measurement, compound 4: 1.5-fold (0.18 log units) above, within the range that was stated.
By their numbers in this assay, from the lowest: compounds 1, 2 and 4 (each within the scatter of the next). At a limit, above all of these: compound 3.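

At this aromatic carbon, meta to a large group, nitro in place of hydroxy now has a measured effect: in this assay the change gives an at least 4.5-fold lower number from compound 3 to compound 4 (0.65 log units; beyond the scatter). Compound 3 gives only a limit, so this step shows a smallest size and not an exact one: the limit of > 15000 nM in this assay, at which 1 of the 4 values shown sits.

The compounds shown leave open whether the step follows from losing the hydrogen-bond donor of hydroxy or from nitro itself. They also leave open how an amine or a carboxylic acid would compare at this place.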